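A smaller group on the amine nitrogen

The source may report more compounds than this note shows. Statements on the series, on what has been measured and on what is new or still open speak of the compounds shown alone.

Measured compounds:
compound 1 `CN(Cc1c(O)ccc2oc(Cc3ccccc3)cc12)C1CCCCC1` gives 12000 nM
compound 2 `Oc1ccc2oc(Cc3ccccc3)cc2c1CN1CCc2ccccc2C1` gives 16000 nM

Of the compounds shown here, two have been measured in a functional assay on SQ20B cells (Homo sapiens) for cytotoxicity, read by MTT assay, with a stated time of 72 h; a higher number here means a weaker inhibitor, a lower number a stronger inhibitor. Compound 1 gives 12000 nM, and compound 2 gives 16000 nM. The number for compound 1 is the lower of the two, but the gap to compound 2 lies within the scatter, so the two values show no difference that can be read as order.

Compound 3 `CON(C)Cc1c(O)ccc2oc(Cc3ccccc3)cc12` shares the core of compound 1 and differs from it in one place: methoxy in place of cyclohexyl on an amine nitrogen. For the measured compounds named here, no step between measured compounds is available to calibrate what such a change does in this assay, so the expectation rests on the weak values of compound 1 and compound 2 alone. The change is expected to move the number upward by a moderate amount, toward a weaker inhibitor, though a result within the scatter would not be surprising; this step is estimated as a 2.5-fold higher number from compound 1 to compound 3 (0.40 log units; beyond the scatter).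

For compound 3 the estimated value in this assay is 30000 nM, with a range from 10000 nM to 100000 nM.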

Compound 3, half-maximal inhibitory concentration: 40000 nM
Compound 3: middle estimate off by 1.3-fold (0.12 log units), on the low side; measured number inside the range.
By their numbers in this assay, from the lowest: compounds 1 and 2 (each within the scatter of the next); then compound 3.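

In this assay, for the compounds shown here, methoxy in place of cyclohexyl on an amine nitrogen gives a 3.3-fold higher number from compound 1 to compound 3 (0.52 log units; beyond the scatter), the first single change in this set with a readable effect, and it runs toward a weaker inhibitor. The step is modest, but it shows that this amine nitrogen substituent influences the number and that, in this pair, cyclohexyl is the better of the two groups, even though compound 1 is itself weak at 12000 nM. Because the exchange removes the carbon ring, shortens the substituent and introduces a hydrogen-bond acceptor all at once, this one step cannot assign the loss to any of these differences, and no measurement offered here explains it.

From the compounds shown here alone, whether the ring, the size of the group or the oxygen matters most remains open; a pair such as an isopropyl group and a tetrahydropyranyl ring on the same nitrogen would begin to separate these differences. Going by these compounds, it also remains open whether any group at this position, such as a benzyl group or a longer chain, can bring the number well below that of compound 1.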